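Cytotoxicity notes: amine replacement on the aryl ketone core

The compounds below may be only part of what the source reports. "The series", "measured", "known", "first", "only" and "open" are said of these compounds alone.

Measured so far:
compound 1 `CN1CCN(c2ccc(C(=O)C3CC3c3ccc(Cl)cc3)cc2)CC1` — 82.1 ug/mL
compound 2 `O=C(c1ccc(NCc2ccco2)cc1)C1CC1c1ccc(Cl)cc1` — 256 ug/mL

In an ADME assay on Vero cells (Chlorocebus sabaeus) for cytotoxicity, with a stated time of 72 h (a higher number here means that more compound is tolerated, a lower number that less compound is tolerated), compound 1 gives the lowest of the two numbers; its nearest neighbour, compound 2, gives 256 ug/mL. Among the compounds with values here, the one step between them, a 3.1-fold higher number from compound 1 to compound 2 (0.49 log units; beyond the scatter), is the only measured change at this position of the shared core.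

Compound 3 `CN(C)c1ccc(C(=O)C2CC2c2ccc(Cl)cc2)cc1` differs from compound 1 as follows: dimethylamino in place of 4-methylpiperazin-1-yl on an aromatic carbon. Within the data shown here, the single step that bears on this change is a 3.1-fold higher number from compound 1 to compound 2 (0.49 log units; beyond the scatter), which swapped the same group for a different amine and lifted the number modestly. Among the measured compounds shown here, no measured step replaces the 4-methylpiperazin-1-yl with dimethylamino directly, so the expectation rests on that one precedent only. The step from compound 1 to compound 3 is expected to be a 1.3-fold higher number from compound 1 to compound 3 (0.13 log units; within the scatter), at most modest and possibly within the scatter. For compound 3 in this assay the estimate is 110 ug/mL, with a range from 45 ug/mL to 260 ug/mL.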

Compound 3, half-maximal cytotoxic concentration: 344 ug/mL
Beside the measured number, compound 3's estimate is 3.1-fold (0.50 log units) below it; measured number above the stated range.
By their numbers in this assay, from the lowest: compound 1; then compounds 2 and 3 (each within the scatter of the next).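

In this assay a second replacement of the 4-methylpiperazin-1-yl on the aromatic carbon, now by dimethylamino, gives a 4.2-fold higher number from compound 1 to compound 3 (0.62 log units; beyond the scatter) and so joins the earlier step, leaving compound 1 apart from the other two compounds. The two replacing groups are not separated, since a 1.3-fold higher number from compound 2 to compound 3 (0.13 log units; within the scatter) is all that lies between them. The data shown offer no explanation for the size of either step.

The compounds shown leave open whether the lower number of compound 1 goes with the six-membered non-aromatic ring or with its second nitrogen. A morpholin-4-yl or piperidin-1-yl group in the same place would bear on that question, as would an unsubstituted amine for the lower end of group size.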